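This account rests on a few compounds, and the source may have more. Where it says the series, first, only, none or still open, it means among the compounds named here.

Measured in an ADME assay on the whole organism (Mus musculus, strain CD-1) for pharmacokinetics, at a dose of 10 mg/kg by the oral route; a higher number here means more compound in the circulation at the dose given, a lower number less compound in the circulation:
- compound 1 `CCOc1cc([C@](O)(CCN(C)C)[C@@H](c2cc3cc(Br)ccc3nc2OC)c2cccc(OC)c2F)cc(OC)n1`: 4000 ng.h/mL
- compound 2 `COc1cc([C@](O)(CCN(C)C)[C@@H](c2cc3cc(Br)ccc3nc2OC)c2cccc(OC)c2F)cc(SC)n1`: 4600 ng.h/mL

Not yet measured: compound 3 `CCSc1cc([C@](O)(CCN(C)C)[C@@H](c2cc3cc(Br)ccc3nc2OC)c2cccc(OC)c2F)cc(SCC)n1`.

Compound 2, at 4600 ng.h/mL, cannot be told apart from compound 1, at 4000 ng.h/mL. Among the measured compounds shown here, the two numbers lie within the scatter of each other, so compound 2 stands level with the only other measured compound.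

The next change is a group of 12 heavy atoms (9 carbon, 1 nitrogen, 2 sulfur; one six-membered aromatic ring with 1 hetero atom) in place of a group of 10 heavy atoms (7 carbon, 1 nitrogen, 1 oxygen, 1 sulfur; one six-membered aromatic ring with 1 hetero atom), on a saturated chain carbon bound to an oxygen on a saturated carbon and two saturated chain carbons. For the measured compounds named here, no measured step covers this exact swap. Going by the values given here, the closest guide is the single step of a 1.2-fold higher number from compound 1 to compound 2 (0.06 log units; within the scatter), which puts methylsulfanyl in place of ethoxy on an aromatic carbon. That step also exchanges an oxygen-linked group for a sulfur-linked one, but it rests on one pair and touches only part of what changes here.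

On that evidence, no step beyond the scatter is expected in this assay, in either direction. The expected step is a 1.1-fold lower number from compound 2 to compound 3 (0.04 log units; within the scatter). Compound 3 is estimated at 4200 ng.h/mL, with an expected range of 1900 ng.h/mL to 9000 ng.h/mL.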

Compound 3, area under the concentration-time curve: 11900 ng.h/mL
Beside the measured number, compound 3's estimate is 2.8-fold (0.45 log units) below it; the measured number lies above the stated range.
By their numbers in this assay, from the lowest: compounds 1 and 2 (each within the scatter of the next); then compound 3.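

In this assay, the group on the saturated chain carbon bound to an oxygen on a saturated carbon and two saturated chain carbons now gives a response beyond the scatter: there is a 2.6-fold higher number from compound 2 to compound 3 (0.41 log units; beyond the scatter) and a 3.0-fold higher number from compound 1 to compound 3 (0.47 log units; beyond the scatter), whereas the earlier swap gave only a 1.2-fold higher number from compound 1 to compound 2 (0.06 log units; within the scatter). The position is therefore not indifferent to change, and of the three groups shown, only the group of 12 heavy atoms (9 carbon, 1 nitrogen, 2 sulfur), the one without oxygen, stands clear of the other two. Nothing measured in this set bears on why the number rises.

Still open, on these data alone, is whether the rise follows the second sulfur, the longer chains on sulfur or the two together, and whether a longer chain such as propylsulfanyl or an amine on the same aromatic ring would extend it or lose it. A single area under the curve at one oral dose also leaves open how much of the rise lies in uptake and how much in removal from the circulation.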